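The source may hold more compounds than are shown below. What is called first, only, known or untested is meant among the compounds shown, and "the series" means these compounds.

Working notes on the series. Compound 3 `CCN(CC)C(=O)Nc1ncc(C(Oc2ccc3cc(Br)ccc3c2)c2ccc(Cl)cc2)s1` carries a diethylcarbamoyl group on a nitrogen on an aromatic ring whose other neighbours are aromatic carbon; in an ADME assay on HepG2 2.2.15 cells (Homo sapiens) for cytotoxicity (a higher number here means that more compound is tolerated, a lower number that less compound is tolerated), compound 3 gives "not toxic" (no number reported). No single number therefore stands for compound 3; of the two further entries in this assay, one is a limit and one is an entry without a number. Compound 1 `CC(C)(C)OC(=O)Nc1ncc(C(Oc2ccc(Cc3ccccc3)cc2)c2ccc(Cl)cc2)s1` gives > 50000 nM in this assay, which is a limit of the assay and not a number. Compound 1 thus sits at the limit of > 50000 nM in this assay, at which 1 of the 3 values shown sits. Compound 2 `O=C(Nc1ncc(C(OCc2ccc3ccccc3c2)c2ccccc2)s1)c1cccs1` gives "not toxic" (no number reported) in this assay. Compound 4 `O=S(=O)(Nc1ncc(C(Oc2ccc3cc(Br)ccc3c2)c2ccc(Cl)cc2)s1)c1ccc2c(c1)CCO2` has not yet been measured. The change from compound 3 to compound 4 is a group of 12 heavy atoms (8 carbon, 3 oxygen, 1 sulfur; one five-membered non-aromatic ring with 1 hetero atom, one six-membered aromatic ring of carbon only) in place of a group of 7 heavy atoms (5 carbon, 1 nitrogen, 1 oxygen; no ring), on a nitrogen on an aromatic ring. Going by the values given here, no step between two measured compounds differing at a single site is available, so the size of the step in this assay cannot be read from the series; no step beyond the usual scatter is expected, and the result will most probably again be reported as a limit rather than a number. For compound 4 the expected value in this assay is estimated at 50000 nM, with a range from 20000 nM to 100000 nM.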

Compound 4, half-maximal cytotoxic concentration: > 50000 nM
Compound 4: only a limit was reported (the forecaster's own chance of this, stated with the estimate: 70%); the middle value sits exactly at the limit.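

Compound 4 gives > 50000 nM in this assay, which is a limit of the assay. Going by these compounds alone, compound 3 has no single number, so no step from compound 3 to compound 4 can be read. The compounds shown leave open where any of them would reach a half-maximal cytotoxic concentration: the limit of > 50000 nM in this assay, at which 2 of the 4 values shown sit.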